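This account rests on a few compounds, and the source may have more. Where it says the series, first, only, none or still open, it means among the compounds named here.

Compound 1 `O=C(O)/C(S)=C/c1cccc(F)c1` gives 31500 nM in an assay on isolated protein for inhibition of Calpain-1 catalytic subunit (Sus scrofa) (on this read-out higher numbers stand for weaker inhibition and lower numbers for stronger inhibition), the higher of the two numbers recorded so far. Compound 2 `O=C(O)/C(S)=C/c1c[nH]c2cccc(Cl)c12` gives 140 nM in this assay, a much lower number. Compound 3 `O=C(O)/C(S)=C/c1cccc(Cl)c1` differs from compound 1 by chloro in place of fluoro on an aromatic carbon. Among the measured compounds shown here, no measured pair shows this change, so only a small step is expected, probably within the usual scatter, perhaps leaning toward a lower number. Compound 3 is expected to give about 20000 nM in this assay, with a range from 8000 nM to 60000 nM. The expected step for compound 3 is a 1.6-fold lower number from compound 1 to compound 3 (0.20 log units; within the scatter).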

Compound 3, half-maximal inhibitory concentration: 13100 nM
For compound 3 the middle estimate is 1.5-fold (0.18 log units) above the measured one, within the range that was stated.
By their numbers in this assay, from the lowest: compound 2; then compound 3; then compound 1.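

Swapping fluoro for chloro on this aromatic carbon gives a 2.4-fold lower number from compound 1 to compound 3 (0.38 log units; beyond the scatter) in this assay, so this position is sensitive to which halogen it carries, although the step is modest. This is a single pair, so it shows one change on one core and no general rule. No available evidence explains why the chloro compound gives the lower number.

Going by these compounds, it remains open whether bromo would extend the step. A methoxy group or an amine at this position could also give a number on either side.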